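A few compounds are considered here, and "the series" means these few. Any claim that something is new, unique, unknown or untested is made for them only; others in the source may bear on it.

Working notes on the series. The shared core is that of compound 1 `Cc1ccc(-c2cn(C/C=C3\OC(=O)C(OCc4ccccc4)=C3OCc3ccccc3)nn2)cc1`. In a functional assay on MCF7 cells (Homo sapiens) for antiproliferative activity, read by MTT assay, with a stated time of 72 h (a higher number here means a weaker inhibitor, a lower number a stronger inhibitor), compound 1 gives a limit of the assay, > 100000 nM. Compound 2 `CCCCCc1ccc(-c2cn(C/C=C3\OC(=O)C(OCc4ccccc4)=C3OCc3ccccc3)nn2)cc1` carries butyl in place of hydrogen on a saturated chain carbon bound to an aromatic carbon. In this assay compound 2 also gives a limit, > 100000 nM. The step that the two limits leave unreadable from compound 1 to compound 2 is therefore not readable in size. Among the compounds with values here, compound 3 `O=C1O[C@H]([C@@H](O)Cn2cc(CNS(=O)(=O)c3ccc(Cl)cc3)nn2)C(OCc2ccccc2)=C1OCc1ccccc1` differs from both in several places at once, so no single step is drawn to it. In this assay compound 3 gives 4170 nM, a number rather than a limit. On the numbers shown, compound 2 stands at the limit, together with compound 1 (the limit of > 100000 nM in this assay, at which 2 of the 3 values shown sit), and compound 3 is the only one with a number.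

Compound 4 `O=C1O/C(=C\Cn2cc(-c3cccc(O)c3)nn2)C(OCc2ccccc2)=C1OCc1ccccc1` is not yet measured. It differs from compound 2 by 3-hydroxyphenyl in place of 4-pentylphenyl on an aromatic carbon. Within the data shown here, the only measured step at that site, from compound 1 to compound 2, is unreadable, so no measured step gives a size for this change. The change may keep compound 4 at the limit or may bring it toward the range where compound 3 sits. The expected step is an at least 1.4-fold lower number from compound 2 to compound 4 (0.15 log units; that floor lies within the scatter). The estimate for compound 4 in this assay is 70000 nM, with a range from 15000 nM to 200000 nM.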

Compound 4, half-maximal inhibitory concentration: 27800 nM
Beside the measured number, compound 4's estimate is 2.5-fold (0.40 log units) above it; the range from low to high includes it.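

Within the data shown here, the only readable change at this position on the shared core in this assay is an at least 3.5-fold lower number from compound 2 to compound 4 (0.55 log units; beyond the scatter), and the same group replacing 4-methylphenyl gives an at least 3.5-fold lower number from compound 1 to compound 4 (0.55 log units; beyond the scatter). Both sizes are floors, because the two starting compounds stand at a limit of the assay: the limit of > 100000 nM in this assay, at which 2 of the 4 values shown sit. So the group on this aromatic carbon of the five-membered ring can move the read-out off that limit, which the unreadable step between the two alkyl-substituted phenyl groups could not show.

The replacement removes the alkyl chain and brings in the hydroxyl at once, with one hydrogen-bond donor and one acceptor entering, so the compounds shown do not separate these two parts of the change, and a plain phenyl, 3-methoxyphenyl or 3-aminophenyl group on the same carbon would bear on that question. Among these compounds, compound 3 differs from compound 4 in several places, so its value gives no step here, and how far the series can move through this position alone remains open.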